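The source may hold more compounds than are shown below. What is called first, only, known or untested is meant among the compounds shown, and "the series" means these compounds.

Of the compounds shown here, three have been measured in a functional assay on A375P cells (Homo sapiens) for antiproliferative activity; a higher number here means a weaker inhibitor, a lower number a stronger inhibitor. Compound 1 `CC(=O)Nc1cc(NC(=O)Nc2ccc(Cl)c(Cl)c2)ccc1C` gives 2100 nM, compound 2 `CC(=O)Nc1cc(NC(=O)Nc2cc(C(F)(F)F)cc(C(F)(F)F)c2)ccc1C` gives 685 nM, and compound 3 `Cc1ccc(NC(=O)Nc2ccc(Cl)c(Cl)c2)cc1NC(=O)c1ccccc1` gives 5800 nM, so compound 2 gives the lowest of the three numbers. Compound 1 and compound 3 differ by phenyl in place of methyl on a carbonyl carbon, and that single change produced a 2.8-fold higher number from compound 1 to compound 3 (0.44 log units; beyond the scatter). How the cores of compound 1 and compound 2 differ is not broken down here. Compound 4 `Cc1ccc(NC(=O)Nc2cc(C(F)(F)F)cc(C(F)(F)F)c2)cc1NC(=O)c1ccccc1` has not yet been measured in this assay; it differs from compound 2 by phenyl in place of methyl on a carbonyl carbon, the same change as between compound 1 and compound 3, made at the same place. Compound 4 is therefore expected to show a 2.8-fold higher number from compound 2 to compound 4 (0.44 log units; beyond the scatter), an expectation that rests on a 2.8-fold higher number from compound 1 to compound 3 (0.44 log units; beyond the scatter). On that basis compound 4 is estimated at 1900 nM, between 900 nM and 4500 nM.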

Compound 4, half-maximal inhibitory concentration: 162 nM
Estimate against measurement, compound 4: 12-fold (1.07 log units) above, and the stated range ends above it.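

In this assay, phenyl in place of methyl on a carbonyl carbon gave a 4.2-fold lower number from compound 2 to compound 4 (0.63 log units; beyond the scatter), a step in the opposite direction to the one seen on the core of compound 1. Set side by side, the two steps do not agree: the same change on two cores in this assay, a 2.8-fold higher number (0.44 log units; beyond the scatter) from compound 1 to compound 3 and a 4.2-fold lower number (0.63 log units; beyond the scatter) from compound 2 to compound 4, 12-fold (1.07 log units) apart, beyond the scatter of two such steps. The change from acetamido to benzamido therefore did not carry from one core to the other in this series, although two pairs cannot show why the direction reversed or which difference between the cores decides it.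

The compounds shown leave open how other groups on that carbonyl carbon, such as a longer alkyl chain or a pyridine ring, would behave on either core. They also leave open which direction the step would take on a third core, such as one carrying a methoxy group.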